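Para substituent swap on a chalcone-like benzoxaborole

A few compounds are considered here, and "the series" means these few. Any claim that something is new, unique, unknown or untested is made for them only; others in the source may bear on it.

Two cinnamoyl compounds sharing one core were tested in a toxicity assay on WI-38 cells (Homo sapiens) for cytotoxicity, read by MTT assay, with a stated time of 48 h; on this read-out higher numbers stand for weaker inhibition and lower numbers for stronger inhibition. Compound 1 `O=C(/C=C/c1ccc2c(c1)B(O)OC2)c1cccs1` gives 26000 nM there, and compound 2 `O=C(/C=C/c1ccc2c(c1)B(O)OC2)c1ccc(Cl)cc1` gives 24700 nM; the two numbers sit within the scatter of each other, as the step of a 1.1-fold lower number from compound 1 to compound 2 (0.02 log units; within the scatter) shows. Compound 3 `Cc1ccc(C(=O)/C=C/c2ccc3c(c2)B(O)OC3)cc1` differs from compound 2 by methyl in place of chloro on an aromatic carbon. Among the measured compounds shown here, only that one step bears on this change, and it was small, so no step beyond the scatter is expected in this assay for compound 3, with a 1.0-fold higher number from compound 2 to compound 3 (0.01 log units; within the scatter). Compound 3 is therefore estimated at 25000 nM, in a range from 10000 nM to 60000 nM.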

Compound 3, half-maximal inhibitory concentration: 22200 nM
Compound 3: middle estimate off by 1.1-fold (0.05 log units), on the high side; the range from low to high includes it.
By their numbers in this assay, from the lowest: compounds 3, 2 and 1 (each within the scatter of the next).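

Chloro and methyl cannot be told apart at this position para to a large group in this assay, with a 1.1-fold lower number from compound 2 to compound 3 (0.05 log units; within the scatter) between them, which adds a second group on this aromatic carbon to the earlier comparison of aryl groups. The 4-methylphenyl group likewise stands level with thiophen-2-yl on the carbonyl carbon, with a 1.2-fold lower number from compound 1 to compound 3 (0.07 log units; within the scatter) on that swap. Nothing available explains these close numbers. As far as these compounds go, whether an amine, a carboxylic acid or a longer chain at this position would give a number beyond the scatter stays open, as does the effect of any change to the shared core.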